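This account rests on a few compounds, and the source may have more. Where it says the series, first, only, none or still open, it means among the compounds named here.

Going by the values given here, in a functional assay on MIA PaCa-2 cells (Homo sapiens) for antiproliferative activity (a higher number here means that more compound is needed for the effect, a lower number that less compound is needed), compound 2 `C#CCCNC(=O)c1cccc2c1cc(C)n2-c1nc2c(c(NCc3ccccc3)n1)CCCC2` gives 1410 nM and stands highest of the three numbers measured so far. Compound 3 `CC#CCNC(=O)c1cccc2c1cc(C)n2-c1nc2c(c(NCc3ccccc3)n1)COCC2` gives 524 nM and compound 1 `Cc1cc2c(C(N)=O)cccc2n1-c1nc2c(c(NCc3ccccc3)n1)COCC2` gives 146 nM with both gaps to compound 2 lying beyond the scatter.

Compound 4 `CCC#CC(=O)Nc1cccc2c1cc(C)n2-c1nc2c(c(NCc3ccccc3)n1)CCCC2` is reached through a group of 7 heavy atoms (5 carbon, 1 nitrogen, 1 oxygen; no ring) in place of a group of 7 heavy atoms (5 carbon, 1 nitrogen, 1 oxygen; no ring), on an aromatic carbon and the two have the same atoms, joined differently. Among the compounds with values here, the one measured step, a 3.6-fold higher number from compound 1 to compound 3 (0.55 log units; beyond the scatter) as a modest change, adds a but-2-yn-1-yl on an amide-type nitrogen and rearranges nothing, so it bears on this change only loosely. Within the data shown here, no measured pair shows a rearrangement of this kind, so the data give no direction, and no step beyond the scatter is expected in this assay as the central case. The expected step is a 1.4-fold lower number from compound 2 to compound 4 (0.15 log units; within the scatter) with wide margins on either side. In this assay compound 4 is estimated at 1000 nM with an expected range from 250 nM to 4000 nM as a working figure.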

Compound 4, half-maximal effective concentration: 463 nM
The estimate for compound 4 lay 2.2-fold (0.33 log units) above the measured number; the range from low to high includes it.
By their numbers in this assay, from the lowest: compound 1; then compounds 4 and 3 (each within the scatter of the next); then compound 2.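

In this assay, the position on the aromatic carbon responds to how the side chain is joined, even with its atoms unchanged: the rearrangement gives a 3.0-fold lower number from compound 2 to compound 4 (0.48 log units; beyond the scatter). Going by these compounds alone, this is the first reading at this place, since the earlier step concerned only substitution on an amide-type nitrogen, whereas here the nitrogen rather than the carbonyl sits on the aromatic carbon and the triple bond moves along the chain, two changes that this single step cannot separate. No measurement shown accounts for the step.

Open, from the compounds shown here alone, is whether the triple bond matters at all, which a saturated pentanoyl chain on the same nitrogen would test. Also open, going by these compounds, is whether the same rearrangement gives a similar step on the core of compound 3.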